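Removing a trifluoromethyl group in a macrocyclic quinazoline series

A few compounds are considered here, and "the series" means these few. Any claim that something is new, unique, unknown or untested is made for them only; others in the source may bear on it.

In a functional assay on SH-SY5Y cells (Homo sapiens) for antiproliferative activity, read by MTT assay, with a stated time of 72 h (on this read-out lower numbers stand for stronger inhibition and higher numbers for weaker inhibition), compound 1 `c1ccc(COc2ccccc2Nc2ncnc3cc4c(cc23)OCCOCCO4)cc1` gives 93700 nM. Compound 2 `FC(F)(F)c1ccc(COc2ccccc2Nc2ncnc3cc4c(cc23)OCCOCCO4)cc1` carries a trifluoromethyl group on its benzyl ring, and in this assay compound 2 reaches only the limit of > 100000 nM, a limit rather than a number. The change from compound 2 to compound 1 is hydrogen in place of trifluoromethyl on an aromatic carbon, and it made an at least 1.0-fold lower number from compound 2 to compound 1 (0.02 log units; that floor lies within the scatter). This step can only be read as a floor, because the limit of > 100000 nM in this assay, at which 1 of the 3 values shown sits, caps what compound 2 could show.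

Compound 3 `FC(F)(F)c1ccc(COc2cccc(Nc3ncnc4cc5c(cc34)OCCOCCOCCO5)c2)cc1` keeps the trifluoromethyl-bearing benzyl group but differs from compound 2 in its core and in where the aniline is attached; the difference between the two cores is not broken down here. In this assay compound 3 gives 20000 nM, the lower of the two numbers measured.

Compound 4 `c1ccc(COc2cccc(Nc3ncnc4cc5c(cc34)OCCOCCOCCO5)c2)cc1` has not yet been measured. Relative to compound 3 it differs by hydrogen in place of trifluoromethyl on an aromatic carbon, the same change as from compound 2 to compound 1, at a place described in the same words. For the measured compounds named here, on the one measured step, which was small and bounded by a limit, compound 3 to compound 4 is expected to move by about a 1.1-fold higher number from compound 3 to compound 4 (0.04 log units; within the scatter). Compound 4 is therefore estimated at 22000 nM in this assay, with a likely range from 7000 nM to 70000 nM.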

Compound 4, half-maximal inhibitory concentration: 22800 nM
Beside the measured number, compound 4's estimate is 1.0-fold (0.02 log units) below it, within the range that was stated.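

In this assay, putting hydrogen in place of trifluoromethyl on the benzyl ring gives a 1.1-fold higher number from compound 3 to compound 4 (0.06 log units; within the scatter), so on this core the two numbers cannot be told apart. Set beside the earlier step, on a core that differs in the ring and in where the aniline is attached, the comparison reads: the same change on two cores in this assay, an at least 1.0-fold lower number (0.02 log units; that floor lies within the scatter) from compound 2 to compound 1 and a 1.1-fold higher number (0.06 log units; within the scatter) from compound 3 to compound 4; the limit leaves it open whether they differ. This does not show that the change acts the same way on both cores, or that it would do nothing on the core of compound 1, since compound 2 is recorded only as a limit and not as a number: the limit of > 100000 nM in this assay, at which 1 of the 4 values shown sits.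

The compounds shown carry only trifluoromethyl or hydrogen at this place on the benzyl ring, so it stays open whether another group there, such as a chlorine atom, a methoxy group or an amine, would give a number clearly apart from these. Going by these compounds, the core and the attachment point of the aniline also change together across these compounds, so what each contributes by itself remains open.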